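Working notes: step from compound 3 to compound 4

The source may hold more compounds than are shown below. What is called first, only, known or untested is meant among the compounds shown, and "the series" means these compounds.

In a functional assay on L02 cells (Homo sapiens) for inhibition, read by Griess assay, with stated times of 1 h and 24 h (a lower number here means a stronger inhibitor, a higher number a weaker inhibitor), compound 1 `CCCc1nn(C)c2c(NC3CC3)nc(/C=C/c3nc(C)c(C)nc3C)nc12` gives 706000 nM. For compound 2 `CC(C)c1ccc(Nc2nc(/C=C/c3ccco3)nc3ccsc23)cc1` this assay records only a limit, > 1000000 nM. For compound 3 `CCN1CCN(c2nc(/C=C/c3cc(OC)c(OC)c(OC)c3)nc3ccsc23)CC1` the same holds, and its value in this assay is only a limit, > 1000000 nM. Compound 3 therefore stands at the weak end of what is shown, without a number of its own; two of the three values sit at the limit of > 1000000 nM in this assay, at which 2 of the 3 values shown sit, and only compound 1 yields a measured number. Among the compounds with values here, no two measured compounds differ in one place, so no measured step is available in this assay.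

Compound 4 `COc1cc(/C=C/c2nc(NCc3ccccc3Cl)c3sccc3n2)cc(OC)c1OC` differs from compound 3 by (2-chlorobenzyl)amino in place of 4-ethylpiperazin-1-yl on an aromatic carbon. Within the data shown here, the one other compound carrying an amino substituent on its core, compound 2, is also recorded only as a limit. Nothing shown points to a gain here. The step is expected to be none beyond the scatter, a step that the limit leaves unreadable from compound 3 to compound 4. Compound 4 is expected at 1200000 nM, within 400000 nM to 4000000 nM, and most likely reported again only as a limit.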

Compound 4, half-maximal inhibitory concentration: > 1000000 nM
Compound 4: no number, only a limit; the forecaster's own chance of this, stated with the estimate: 65%; the middle value is on the limit's open side.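

No step can be read from compound 3 to compound 4, as both are recorded in this assay only as limits: the limit of > 1000000 nM in this assay, at which 3 of the 4 values shown sit.

The compounds shown leave open what (2-chlorobenzyl)amino in place of 4-ethylpiperazin-1-yl does in this assay, since neither compound has a number of its own.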